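The source may report more compounds than this note shows. Statements on the series, on what has been measured and on what is new or still open speak of the compounds shown alone.

Working notes on the series.

Compound 1 `NC(=O)C1CCN(c2nc(-c3cccnc3)nc3c2CN(Cc2ccccc2)CC3)CC1` carries the shared core with a benzyl group on the ring amine nitrogen and a piperidine carboxamide on the other side; in an assay on cells with Cystic fibrosis transmembrane conductance regulator variant F508del (Homo sapiens) as the target, read by fluorescence, with stated times of 24 h and 30 min (a higher number here means that more compound is needed for the effect, a lower number that less compound is needed), compound 1 gives 100000 nM. Compound 2 `CN(C)CCN1CCN(c2nc(-c3ccccn3)nc3c2CN(S(=O)(=O)c2ccccc2)CC3)CC1` swaps both of those ends: a phenylsulfonyl on the ring amine nitrogen and a dimethylaminoethyl piperazine on the other side. In this assay compound 2 gives 100000 nM. On the digits shown, compound 2 stands level with compound 1, and the two values lie within the usual scatter of each other, so no order between them can be read.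

Compound 3 `CN(C)CCN1CCN(c2nc(-c3ccccn3)nc3c2CN(C(=O)c2ccccc2)CC3)CC1` keeps the piperazine side of compound 2 unchanged and alters only the ring amine nitrogen: benzoyl in place of phenylsulfonyl on an amine nitrogen in a ring. Going by the values given here, no pair of measured compounds shows what this exchange does. Given that compound 2 sits at 100000 nM, the change is expected to be none beyond the scatter, a step of no change at the digits printed from compound 2 to compound 3 (within the scatter), with the real chance that the readout again reaches only the top of the tested range. For compound 3 in this assay the estimate is 100000 nM, within 20000 nM to 100000 nM.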

Compound 3, half-maximal effective concentration: 100000 nM
Compound 3: the middle estimate sits on the measured number at the digits printed, and the stated range covers the measured number.
By their numbers in this assay, from the lowest: compounds 1, 2 and 3 (each within the scatter of the next).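

Going by these compounds alone, the exchange of phenylsulfonyl for benzoyl on an amine nitrogen in a ring gives the first single-place reading: in this assay it is no change at the digits printed from compound 2 to compound 3 (within the scatter). With the dimethylaminoethyl piperazine side held fixed, the two groups therefore cannot be told apart in this read-out, so the sulfonyl and the carbonyl linker give the same printed value here. No measurement at hand explains this result.

Because compound 2 and compound 3 print the same value, this pair leaves open whether any group on this nitrogen can shift the read-out at all, and an acetyl group or a plain methyl there would test that. As far as these compounds go, it is also open whether the same exchange would read alike with a different group on the other side of the shared core, such as a piperazine bearing a carboxylic acid or a longer chain.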